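The compounds below may be only part of what the source reports. "The series", "measured", "known", "first", "only" and "open" are said of these compounds alone.

Three compounds have been measured so far in a physicochemical assay for solubility (on this read-out higher numbers stand for higher solubility and lower numbers for lower solubility), and give these values:

Compound 1 `C[C@H](Oc1ccc(S(C)(=O)=O)cc1C(=O)N1Cc2ccc(C(F)(F)F)cc2C1)C(F)(F)F` gives 1 ug/mL
Compound 2 `COc1cccc2c1CN(C(=O)c1cc(S(C)(=O)=O)ccc1O[C@@H](C)C(F)(F)F)C2` gives 85 ug/mL
Compound 3 `C[C@H](Oc1ccc(S(C)(=O)=O)cc1C(=O)N1Cc2cc(C(F)(F)F)cnc2C1)C(F)(F)F` gives 280 ug/mL

Compound 1 stands lowest of the three, and the other two lie above it by far more than the usual scatter. Compound 4 `C[C@H](Oc1ccc(S(C)(=O)=O)cc1C(=O)N1Cc2ccc(C3CCCCO3)cc2C1)C(F)(F)F` differs from compound 1 at one place, with oxan-2-yl in place of trifluoromethyl on an aromatic carbon. Among the compounds with values here, no two measured compounds differ in one place only, so nothing here shows directly what this swap does. The values of compound 2 (85 ug/mL) and compound 3 (280 ug/mL) show only that related structures can reach much higher numbers than compound 1 does. A moderate rise in this assay, beyond the scatter but short of those two compounds, is therefore expected. The expected step is a 10-fold higher number from compound 1 to compound 4 (1.00 log units; beyond the scatter) as a rough estimate. Compound 4 is estimated at 10 ug/mL with an expected range from 2 ug/mL to 60 ug/mL as a deliberately wide band.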

Compound 4, solubility: < 1 ug/mL
Compound 4 was reported as a limit; the forecaster's own chance of this, stated with the estimate: 10%; middle value at least 10-fold (1.00 log units) from the limit.
By their numbers in this assay, from the lowest: compound 1; then compound 2; then compound 3.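

Within the data shown here, this is the first direct look at a single change at this position on the core of compound 1, and it gives a number no higher from compound 1 to compound 4 (the limit leaves the size open). In this assay, compound 4 gives < 1 ug/mL, which is a limit of the assay and not a number. Replacing trifluoromethyl with oxan-2-yl brings in a six-membered non-aromatic ring and one hydrogen-bond acceptor, yet this swap gives no rise on this read-out, and the result rests on one such limit: the limit of < 1 ug/mL in this assay, at which 1 of the 4 values shown sits.

The compounds shown leave open how far compound 4 actually lies from compound 1, as well as whether an amine or a carboxylic acid on this same aromatic carbon would raise the number. They also leave open whether oxan-2-yl in place of trifluoromethyl would behave in the same way on the core of compound 3.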